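A few compounds are considered here, and "the series" means these few. Any claim that something is new, unique, unknown or untested is made for them only; others in the source may bear on it.

Among the measured compounds shown here, in a functional assay on A2780 cells (Homo sapiens) for inhibition, with a stated time of 72 h (on this read-out higher numbers stand for weaker inhibition and lower numbers for stronger inhibition), compound 1 `CC(=O)O[C@@]1([C@@H]2/C(C)=C(/O)C(=O)C3=C(C)[C@@H](OC(=O)[C@H](O)[C@H](C=C(C)C)NC(=O)OC(C)(C)C)C[C@@](O)([C@H]2OC(=O)c2cccc(Cl)c2)C3(C)C)CO[C@@H]1CCO` gives 4.6 nM and compound 2 `CC(=O)O[C@@]1([C@@H]2/C(C)=C(/O)C(=O)C3=C(C)[C@@H](OC(=O)[C@H](O)[C@H](C=C(C)C)NC(=O)OC(C)(C)C)C[C@@](O)([C@H]2OC(=O)c2cccc(F)c2)C3(C)C)CO[C@@H]1CCO` gives 6.1 nM, so compound 1 stands level with its only measured neighbour. That step, a 1.3-fold higher number from compound 1 to compound 2 (0.12 log units; within the scatter), is fluoro in place of chloro on an aromatic carbon. Compound 3 `CC(=O)O[C@@]1([C@@H]2/C(C)=C(/O)C(=O)C3=C(C)[C@@H](OC(=O)[C@H](O)[C@H](CC(C)C)NC(=O)OC(C)(C)C)C[C@@](O)([C@H]2OC(=O)c2cccc(Cl)c2)C3(C)C)CO[C@@H]1CCO` instead differs from compound 1 by isobutyl in place of 2-methylprop-1-en-1-yl on a saturated chain carbon bound to an amide-type nitrogen and a saturated chain carbon. For the measured compounds named here, no measured step tests this change, so no shift beyond the scatter is expected. Compound 3 is estimated at 6 nM, within an expected range of 2.5 nM to 15 nM. The estimate amounts to an expected 1.3-fold higher number from compound 1 to compound 3 (0.12 log units; within the scatter).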

Compound 3, half-maximal inhibitory concentration: 5.5 nM
Beside the measured number, compound 3's estimate is 1.1-fold (0.04 log units) above it; the measured number falls inside the stated range.
By their numbers in this assay, from the lowest: compounds 1, 3 and 2 (each within the scatter of the next).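

In this assay, the step at this saturated chain carbon, bound to an amide-type nitrogen and a saturated chain carbon, is a 1.2-fold higher number from compound 1 to compound 3 (0.08 log units; within the scatter). Where the earlier compounds tested only the aromatic halogen, this shows that the side chain can lose its double bond, with isobutyl in place of 2-methylprop-1-en-1-yl, without a shift beyond the scatter. Nothing available explains this result. The compounds shown leave open whether a phenyl ring or a longer chain on this carbon would give a similar number, and whether isobutyl would do so alongside fluoro in place of chloro.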